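The source may hold more compounds than are shown below. What is called first, only, known or untested is meant among the compounds shown, and "the series" means these compounds.

Measured compounds in an ADME assay on L02 cells (Homo sapiens) for antiproliferative activity, read by MTT assay, with a stated time of 48 h; on this read-out higher numbers stand for weaker inhibition and lower numbers for stronger inhibition:
- compound 1, `N#CC1=C(N)Oc2c(c3nc4ccccc4nc3c3ccccc23)C12C(=O)N(Cc1cnnn1-c1cccc(Cl)c1)c1ccccc12`: 35200 nM
- compound 2, `N#CC1=C(N)Oc2c(c3nc4ccccc4nc3c3ccccc23)C12C(=O)N(Cc1cnnn1-c1ccc(Br)cc1)c1ccccc12`: a limit, > 50000 nM
- compound 3, `N#CC1=C(N)Oc2c(N)cc3nc4ccccc4nc3c2C12C(=O)N(Cc1cnnn1-c1cccc(C(F)(F)F)c1)c1ccccc12`: 38100 nM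

Compound 3 stands alongside compound 1, the two numbers lying within the usual scatter of each other. Compound 2 reports only a limit, (the limit of > 50000 nM in this assay, at which 1 of the 3 values shown sits), so its position cannot be placed among the numbers.

Compound 4, `Cc1cc(C)cc(-n2nncc2CN2C(=O)C3(C(C#N)=C(N)Oc4c(N)cc5nc6ccccc6nc5c43)c3ccccc32)c1`, has not yet been measured in this assay. It differs from compound 3 in one place: 3,5-dimethylphenyl in place of 3-(trifluoromethyl)phenyl on an aromatic nitrogen

Going by the values given here, one measured step bears on this, since it also exchanges the aryl group on the same aromatic nitrogen: an at least 1.4-fold higher number from compound 1 to compound 2 (0.15 log units; that floor lies within the scatter). That step stayed within the scatter, and the compounds with this shared core give numbers close to one another throughout, so no step beyond the scatter is expected in this assay in either direction. The estimated step is a 1.0-fold higher number from compound 3 to compound 4 (0.02 log units; within the scatter). For compound 4 the expected value is 40000 nM, within a range from 15000 nM to 100000 nM.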

Compound 4, half-maximal inhibitory concentration: > 50000 nM
Compound 4 gave a limit, no number (the forecaster's own chance of this, stated with the estimate: 35%); at least 1.2-fold (0.09 log units) between middle value and limit.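

In this assay, placing 3,5-dimethylphenyl on the aromatic nitrogen instead of 3-(trifluoromethyl)phenyl gives an at least 1.3-fold higher number from compound 3 to compound 4 (0.11 log units; that floor lies within the scatter). Compound 4 reports a limit, not a number, so this step is only a floor and the true size of the change cannot be read. What is new is that an aryl exchange at this position on the core of compound 3 also ends at a limit, as the exchange from compound 1 to compound 2 did on its own core: the limit of > 50000 nM in this assay, at which 2 of the 4 values shown sit.

Every group shown on this nitrogen is a substituted phenyl ring, so it remains open how the number responds to anything else there. A cyclohexyl ring, a longer alkyl chain, or a phenyl ring carrying an amine or a carboxylic acid would each explore that question.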